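Series notes: replacing the 4-cyanophenyl amine substituent

The source may report more compounds than this note shows. Statements on the series, on what has been measured and on what is new or still open speak of the compounds shown alone.

Among the compounds with values here, compound 1 `CC(=O)NC[C@H]1CN(c2ccc(OC[C@H](O)CNc3ccc(C#N)cc3)c(F)c2)C(=O)O1` gives 1.29 in a physicochemical assay for lipophilicity, read by HPLC (on this read-out higher numbers stand for higher lipophilicity and lower numbers for lower lipophilicity), the highest of the three numbers measured so far. Compound 2 `CC(=O)NC[C@H]1CN(c2ccc(OC[C@H](O)CNc3ccncc3)c(F)c2)C(=O)O1` gives 0.02 in this assay, and compound 3 `CC(=O)NC[C@H]1CN(c2ccc(OC[C@H](O)CNC3CC3)c(F)c2)C(=O)O1` gives -0.1 in this assay. Both steps away from compound 1 are large: a number 1.27 log units lower from compound 1 to compound 2 (beyond the scatter) and a number 1.39 log units lower from compound 1 to compound 3 (beyond the scatter). Between compound 2 and compound 3 the step is a number 0.12 log units lower from compound 2 to compound 3 (within the scatter), so those two are not separated.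

Compound 4 `CC(=O)NC[C@H]1CN(c2ccc(OC[C@H](O)CNCCC(C)C)c(F)c2)C(=O)O1` is not yet measured. Its difference from compound 1 is isopentyl in place of 4-cyanophenyl on an amine nitrogen. The measured steps that bear on this change are those from compound 1 to compound 2 and to compound 3, each removing the 4-cyanophenyl group from the amine nitrogen and each lowering the read-out well beyond the scatter. Within the data shown here, the closest precedent is compound 3, where cyclopropyl, a group without ring aromaticity or acceptors, gave -0.1; isopentyl is likewise aromatic-ring-free and acceptor-free, but is a longer five-carbon chain. A drop from compound 1 is therefore expected, though a smaller one than to compound 3, with a number 1.39 log units lower from compound 1 to compound 3 (beyond the scatter) as the lower bound of the precedent. The expected step is a number 0.49 log units lower from compound 1 to compound 4 (beyond the scatter). For compound 4 the estimate is 0.8, between 0.3 and 1.4.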

Compound 4, partition coefficient: 1.19
The estimate for compound 4 lay 0.39 log units below the measured number; the range from low to high includes it.
By their numbers in this assay, from the lowest: compounds 3 and 2 (each within the scatter of the next); then compounds 4 and 1 (each within the scatter of the next).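

In this assay the change to isopentyl gives a number 0.10 log units lower from compound 1 to compound 4 (within the scatter) and leaves the two groups unseparated, so losing the 4-cyanophenyl group, with its aromatic ring and nitrile, does not by itself bring the large drops seen earlier. The read-out at this amine nitrogen instead turns on which group enters: isopentyl in place of cyclopropyl gives a number 1.29 log units higher from compound 3 to compound 4 (beyond the scatter) and isopentyl in place of pyridin-4-yl gives a number 1.17 log units higher from compound 2 to compound 4 (beyond the scatter) on the same core. No measurement at hand explains these differences.

Open, from the compounds shown here alone, is whether chain length or branching carries the isopentyl result, which a straight pentyl chain, a propyl chain or a cyclohexyl group would test. Also open, going by these compounds, is how an unsubstituted phenyl group would read, which would separate the nitrile from the aromatic ring.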